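The compounds below may be only part of what the source reports. "The series", "measured", "known", "first", "only" and "open" are said of these compounds alone.

Compound 1 `CC(C)n1nc(C(=O)N[C@H]2COc3ccccc3N(C)C2=S)nc1Cc1ccccc1`: 360 nM
Compound 2 `CN1C(=S)[C@@H](NC(=O)c2nc(Cc3ccccc3)n(CCCC(F)(F)F)n2)COc2ccccc21`: 2380 nM

In a functional assay on HT-29 cells (Homo sapiens) for inhibition, read by luminescence and CellTiter-Glo, with a stated time of 24 h (on this read-out higher numbers stand for an effect only at larger amounts of compound and lower numbers for an effect already at smaller amounts), compound 2 gives 2380 nM, the higher of the two numbers, so it needs the larger amount to show an effect. Compound 3 `CN1C(=S)[C@@H](NC(=O)c2nc(Cc3ccccc3)n(CCCC#N)n2)COc2ccccc21` keeps the same core and differs from compound 2 at the end of the chain: cyano in place of trifluoromethyl on a saturated chain carbon, three bonds along the chain from an aromatic nitrogen.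

Going by the values given here, only one measured step bears on this, a 6.6-fold higher number from compound 1 to compound 2 (0.82 log units; beyond the scatter). It changes the same aromatic nitrogen substituent, but it replaces isopropyl with 4,4,4-trifluorobutyl and does not test cyano. It therefore gives no direction for the new change, only a rough idea of how sensitive this substituent can be. No shift beyond the scatter is expected, though with wide uncertainty. The expected step is a 1.1-fold higher number from compound 2 to compound 3 (0.02 log units; within the scatter). For compound 3 the estimated value is 2500 nM, with an expected range from 700 nM to 8000 nM.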

Compound 3, half-maximal effective concentration: 2400 nM
The estimate for compound 3 lay 1.0-fold (0.02 log units) above the measured number, and the stated range covers the measured number.
By their numbers in this assay, from the lowest: compound 1; then compounds 2 and 3 (each within the scatter of the next).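

In this assay the two end groups read alike on this chain (a 1.0-fold higher number from compound 2 to compound 3 (0.00 log units; within the scatter)), although cyano has fewer heavy atoms than trifluoromethyl and carries one hydrogen-bond acceptor where trifluoromethyl carries none. The gap seen earlier for the fluorinated chain appears again with 3-cyanopropyl in place of isopropyl on the aromatic nitrogen (a 6.7-fold higher number from compound 1 to compound 3 (0.82 log units; beyond the scatter)). Nothing available explains why the two chains read alike or why both stand apart from isopropyl.

The compounds shown leave open whether the number follows the length of the chain or its end group, which a plain butyl chain or the shorter 2-cyanoethyl could help to separate. They also leave open how an amine or a carboxylic acid at the end of the same chain would read.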